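The source may report more compounds than this note shows. Statements on the series, on what has been measured and on what is new or still open speak of the compounds shown alone.

Compound 1, with the structure `c1ccc(-c2ccncn2)c(OCC2=NCCN2)c1`, stands only as a limit on the numbers shown: in a functional assay for activation of Alpha-1D adrenergic receptor (Homo sapiens), read by calcium flux (on this read-out lower numbers stand for an effect already at smaller amounts and higher numbers for an effect only at larger amounts of compound), compound 1 gives < 100000 nM, which is a limit of the assay and not a number. Compound 2, `c1ccc(-c2ccns2)c(OCC2=NCCN2)c1`, is the only one of the three measured compounds with a numerical value, and in this assay compound 2 gives 25.1 nM. Compound 3, `Cc1csc(-c2ccccc2OCC2=NCCN2)n1`, again returns only a limit, and in this assay compound 3 gives < 100000 nM. Compound 4, `Cn1nccc1-c1ccccc1OCC1=NCCN1`, has not been measured; it differs from compound 1 by 1-methyl-1H-pyrazol-5-yl in place of pyrimidin-4-yl on an aromatic carbon. The measured steps that bear on this change are a step that the limit leaves unreadable from compound 1 to compound 2, a step that the two limits leave unreadable from compound 1 to compound 3 and a step that the limit leaves unreadable from compound 2 to compound 3, none of which can be read in size, because two of the three values sit at the limit of < 100000 nM in this assay, at which 2 of the 3 values shown sit. The comparison of compound 2 with compound 3 shows that a five-membered aromatic ring with two hetero atoms can go with either a numerical value or a limit. Compound 4 is therefore estimated, with wide uncertainty, at 1000 nM, between 30 nM and 50000 nM, which would mean a step that the limit leaves unreadable from compound 1 to compound 4.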

Compound 4, half-maximal effective concentration: < 100000 nM
Compound 4: a limit, no number; the forecaster's own chance of this, stated with the estimate: 40%; the middle value does not contradict the limit.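

No step from compound 1, compound 2 or compound 3 to compound 4 can be read in size, because each involves a limit and not a number: the limit of < 100000 nM in this assay, at which 3 of the 4 values shown sit.

The compounds shown leave open how far compound 1, compound 3 and compound 4 lie from compound 2.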